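This account rests on a few compounds, and the source may have more. Where it says the series, first, only, none or still open, it means among the compounds named here.

Compound 1 `COc1cc(-c2nc3cc(/C=C4\SC(=O)NC4=O)ccc3[nH]2)cc(OC)c1OC` gives 3570 nM in a functional assay on A549 cells (Homo sapiens) for inhibition, read by MTT assay, with a stated time of 48 h (on this read-out lower numbers stand for stronger inhibition and higher numbers for weaker inhibition), the highest of the three numbers in the series. Compound 2 `COc1ccc(-c2nc3cc(/C=C4\SC(=O)NC4=O)ccc3[nH]2)cc1OC` gives 570 nM in this assay. The step of a 6.3-fold lower number from compound 1 to compound 2 (0.80 log units; beyond the scatter) corresponds to a hydrogen in place of methoxy on an aromatic carbon. Among the compounds with values here, compound 3 `COc1cc(OC)c(-c2nc3cc(/C=C4\SC(=O)N(CC(=O)N5CCOCC5)C4=O)ccc3[nH]2)cc1OC` gives 660 nM in this assay, but it differs from compound 1 in two places, so no single step is counted for it. Compound 4 `COc1cc(-c2nc3cc(/C=C4\SC(=O)N(Cc5cccc(C)c5)C4=O)ccc3[nH]2)cc(OC)c1OC` carries 3-methylbenzyl in place of hydrogen on an amide-type nitrogen in a ring. Within the data shown here, no measured step alters this nitrogen alone; the only substituted nitrogen belongs to compound 3, whose value of 660 nM shows that substitution there is compatible with a low number. For compound 4 the expected step is a 2.4-fold lower number from compound 1 to compound 4 (0.38 log units; beyond the scatter), a modest lowering. Compound 4 is estimated at 1500 nM, range 400 nM to 6000 nM.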

Compound 4, half-maximal inhibitory concentration: 930 nM
Estimate against measurement, compound 4: 1.6-fold (0.21 log units) above; the range from low to high includes it.
By their numbers in this assay, from the lowest: compounds 2, 3 and 4 (each within the scatter of the next); then compound 1.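

Replacing the amide hydrogen with 3-methylbenzyl on the ring nitrogen, two ring bonds from the ring sulfur, gives a 3.8-fold lower number from compound 1 to compound 4 (0.58 log units; beyond the scatter) in this assay. Within the data shown here, this is the first single-place reading at this nitrogen: on the core of compound 1, a substituent with a six-membered aromatic ring lowers the number rather than raising it. Nothing available accounts for the lowering.

As far as these compounds go, whether the ring methyl contributes remains open, as an unsubstituted benzyl would test. So does the outcome with a longer chain, an amine or a carboxylic acid at this nitrogen.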